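The source may hold more compounds than are shown below. What is called first, only, known or untested is meant among the compounds shown, and "the series" means these compounds.

Measured so far:
compound 2, `O=C(Nc1ccc(S(=O)(=O)Nc2ccccc2)cc1)c1ccc(Br)cc1F`: 479 nM
compound 3, `O=C(Nc1ccc(S(=O)(=O)Nc2ccccc2)cc1)c1ccc(Cl)cc1F`: 3980 nM
compound 1, `O=C(Nc1ccc(S(=O)(=O)NCc2ccccc2)cc1)c1ccc(Cl)cc1Cl`: > 100000 nM, which is a limit of the assay, not a number

In a functional assay on HEK293 cells for agonist activity at probable G-protein coupled receptor 27 (Homo sapiens), read by a luciferase reporter and beta-arrestin recruitment, with a stated time of 10 min (a lower number here means that less compound is needed, a higher number that more compound is needed for the effect), compound 2 stands lowest of the two numbers; compound 3 lies an 8.3-fold higher number from compound 2 to compound 3 (0.92 log units; beyond the scatter) away. Compound 1 gives only (the limit of > 100000 nM in this assay, at which 1 of the 3 values shown sits).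

Compound 4, `O=C(Nc1ccc(S(=O)(=O)Nc2ccccc2)cc1)c1ccc(Cl)cc1Cl`, is not yet measured. Against compound 2 the change is 2,4-dichlorophenyl in place of 4-bromo-2-fluorophenyl on a carbonyl carbon. Among the measured compounds shown here, the one measured step bearing on it is an 8.3-fold higher number from compound 2 to compound 3 (0.92 log units; beyond the scatter), which covers the chloro in place of bromo part; no measured pair covers the exchange of the fluorine. Compound 1 carries the same 2,4-dichlorophenyl and gives only a limit, but differs elsewhere as well. A step toward a higher number is therefore expected, estimated as a 10-fold higher number from compound 2 to compound 4 (1.02 log units; beyond the scatter). Compound 4 is estimated at 5000 nM, between 1000 nM and 30000 nM.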

Compound 4, half-maximal effective concentration: 457 nM
Estimate against measurement, compound 4: 11-fold (1.04 log units) above; measured number outside the range, below it.
By their numbers in this assay, from the lowest: compounds 4 and 2 (each within the scatter of the next); then compound 3. At a limit, above all of these: compound 1.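

In this assay, 2,4-dichlorophenyl in place of 4-bromo-2-fluorophenyl on the carbonyl carbon leaves the number unchanged, a 1.0-fold lower number from compound 2 to compound 4 (0.02 log units; within the scatter), so bromo is not required at this level. Chloro in place of fluoro on an aromatic carbon gives an 8.7-fold lower number from compound 3 to compound 4 (0.94 log units; beyond the scatter), a step beyond the scatter that the bromo-to-chloro step alone did not show. Phenyl in place of benzyl on the sulfonamide nitrogen gives an at least 210-fold lower number from compound 1 to compound 4 (2.34 log units; beyond the scatter), a step read against a limit: the limit of > 100000 nM in this assay, at which 1 of the 4 values shown sits.

Open, as far as these compounds go, is whether a methoxy or an amine on this aromatic ring keeps the number of compound 4. Also open, from the compounds shown here alone, is whether a longer chain on the sulfonamide nitrogen behaves like benzyl.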